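Piperidinyl for diisopropylamino on a chromone dithiocarbamate

The compounds below may be only part of what the source reports. "The series", "measured", "known", "first", "only" and "open" are said of these compounds alone.

Compound 1 `O=c1c(Cl)c(CSC(=S)N2CCCCC2)oc2ccccc12`, compound 2 `CC(C)N(C(=S)SCc1oc2ccccc2c(=O)c1Cl)C(C)C` and compound 3 `COc1ccc2oc(CSC(=S)N(C(C)C)C(C)C)cc(=O)c2c1` share a dithiocarbamate attached to a chromone-type core, and all three were tested in a functional assay on SW480 cells (Homo sapiens) for antiproliferative activity, read by MTT assay, with a stated time of 72 h; on this read-out lower numbers stand for stronger inhibition and higher numbers for weaker inhibition. Compound 1 gives 690 nM, while compound 2 gives 18100 nM. These two differ in a single place, (piperidin-1-yl in place of diisopropylamino on a thiocarbonyl carbon), and this change produced a 26-fold lower number from compound 2 to compound 1 (1.42 log units; beyond the scatter). Compound 3 gives 7200 nM in this assay, standing second highest of the three numbers; the difference between the core of compound 3 and the core of compound 2 is not broken down here. Compound 4 `COc1ccc2oc(CSC(=S)N3CCCCC3)cc(=O)c2c1` has not yet been measured. It stands to compound 3 exactly as compound 1 stands to compound 2: piperidin-1-yl in place of diisopropylamino on a thiocarbonyl carbon, the same change at the same place. Because compound 2 to compound 1 showed a 26-fold lower number from compound 2 to compound 1 (1.42 log units; beyond the scatter), a step of comparable direction and size is expected here, giving an 18-fold lower number from compound 3 to compound 4 (1.26 log units; beyond the scatter). The core of compound 3 differs from that of compound 2, so the carry-over is uncertain. Compound 4 is expected to give about 400 nM, estimated to lie between 120 nM and 1500 nM.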

Compound 4, half-maximal inhibitory concentration: 2300 nM
For compound 4 the middle estimate is 5.8-fold (0.76 log units) below the measured one, and the stated range ends below it.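

Replacing diisopropylamino with piperidin-1-yl on the thiocarbonyl carbon again gave stronger inhibition in this assay, with a 3.1-fold lower number from compound 3 to compound 4 (0.50 log units; beyond the scatter), so the direction of the change held on the core of compound 3. The size of the step did not hold, and the two steps differ by more than repeated measurements would explain: the same change on two cores in this assay, a 26-fold lower number (1.42 log units; beyond the scatter) from compound 2 to compound 1 and a 3.1-fold lower number (0.50 log units; beyond the scatter) from compound 3 to compound 4, 8.4-fold (0.92 log units) apart, beyond the scatter of two such steps These two pairs show that the gain from this change depends on the core, but they do not show which feature of the core is responsible, since the two cores differ in more than one place.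

The compounds shown leave open whether the chloro or the methoxy group goes with the larger step, a question that a core carrying neither group or both groups could help to settle. They also leave open how other amines on the thiocarbonyl carbon, such as morpholine or dimethylamine, would compare with piperidin-1-yl on either core.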